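Working notes on cytotoxicity in the series: toward compound 4

A few compounds are considered here, and "the series" means these few. Any claim that something is new, unique, unknown or untested is made for them only; others in the source may bear on it.

Measured so far:
compound 1 `CCN(CC)c1cc2[nH]c(C3CCCCC3)nc2cc1NC(=O)c1ccc(OC(F)(F)F)cc1`: > 100 ug/mL
compound 2 `CCCN(CCC)c1cc2[nH]c(C3CCCCC3)nc2cc1NC(=O)OCc1ccccc1`: > 100 ug/mL
compound 3 `CCCCOC(=O)Nc1cc2nc(C3CCCCC3)[nH]c2cc1N(CCC)CCC`: > 100 ug/mL

Three compounds have been run in an ADME assay on Vero cells (Chlorocebus sabaeus) for cytotoxicity, read by resazurin assay, with a stated time of 3 days; a lower number here means a stronger inhibitor, a higher number a weaker inhibitor. Compound 1 gives > 100 ug/mL, which is a limit of the assay and not a number. Compound 2 likewise returns only a limit, > 100 ug/mL. Compound 3 also returns a limit, > 100 ug/mL. Compound 1 therefore stands at the limit, and the two further values shown stand there as well. For the measured compounds named here, the single step between measured compounds that differ in one place, a step that the two limits leave unreadable from compound 2 to compound 3, cannot be read in size for the same reason. What the measurements show is simply (the limit of > 100 ug/mL in this assay, at which 3 of the 3 values shown sit).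

Compound 4 `CCN(CC)c1cc2[nH]c(C3CCCCC3)nc2cc1NC(=O)c1ccc(Br)cc1` is still to be measured in this assay. It differs from compound 1 by bromo in place of trifluoromethoxy on an aromatic carbon. Going by the values given here, no measured step touches this change; the only step available concerns another place and is itself unreadable. The step of a number no higher from compound 1 to compound 4 (the limit leaves the size open) is therefore expected to stay within the scatter, with no direction to call. Compound 4 is expected to give 100 ug/mL, in the range 50 ug/mL to 200 ug/mL, most probably reported once more as a limit.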

Compound 4, half-maximal inhibitory concentration: > 100 ug/mL
Compound 4: only a limit was reported (the forecaster's own chance of this, stated with the estimate: 80%); the middle value sits exactly at the limit.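

In this assay compound 4 gives > 100 ug/mL as a limit of the assay and not a number, and the step from compound 1 to compound 4 cannot be read. The compounds shown leave open which change, if any, would bring a value that can be read as a number, with every result so far at one limit: the limit of > 100 ug/mL in this assay, at which 4 of the 4 values shown sit.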